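Swapping an arylmethylamine for a cyclic amine on the pyridine

The source may hold more compounds than are shown below. What is called first, only, known or untested is meant among the compounds shown, and "the series" means these compounds.

Compound 3 `CC(C(=O)NCc1ccc(C(F)(F)F)nc1NCc1cccnc1)c1ccc(NS(C)(=O)=O)c(F)c1` carries a ((pyridin-3-yl)methyl)amino group on its core. In a functional assay on CHO-K1 cells for antagonist activity at transient receptor potential cation channel subfamily V member 1 (Homo sapiens), read by FLIPR (on this read-out lower numbers stand for stronger inhibition and higher numbers for weaker inhibition), compound 3 is recorded as "not active" (no number reported), with no number behind it, so it has no place on the scale shown by the other compounds. For comparison, compound 2 `CC(C(=O)NCc1ccc(C(F)(F)F)nc1NCc1ccccc1)c1ccc(NS(C)(=O)=O)c(F)c1`, which carries a benzyl group at the same position, gives 15.8 nM in this assay, and compound 1 `Cc1ccc(Nc2nc(C(F)(F)F)ccc2CNC(=O)C(C)c2ccc(NS(C)(=O)=O)c(F)c2)cc1C`, with a 3,4-dimethylphenyl group there, gives 39.3 nM. Among the compounds with values here, the one step on record is a 2.5-fold lower number from compound 1 to compound 2 (0.40 log units; beyond the scatter), which shows that a change at this position can shift the number by a modest amount.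

Compound 4 `CC(C(=O)NCc1ccc(C(F)(F)F)nc1N1CC=CCC1)c1ccc(NS(C)(=O)=O)c(F)c1` differs from compound 3 by a group of 6 heavy atoms (5 carbon, 1 nitrogen; one six-membered non-aromatic ring with 1 hetero atom) in place of a group of 8 heavy atoms (6 carbon, 2 nitrogen; one six-membered aromatic ring with 1 hetero atom), on an aromatic carbon. Within the data shown here, compound 3 itself has no number, so no step can be measured from it; the step from compound 1 to compound 2 touches the same position but a different kind of change, and compound 3 shows that the same position can also abolish activity altogether. The expectation for compound 4 is therefore wide and uncertain. Compound 4 is estimated to give about 200 nM in this assay, within a range from 25 nM to 3000 nM.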

Compound 4, inhibition constant: 0.3 nM
Beside the measured number, compound 4's estimate is 670-fold (2.82 log units) above it; the whole stated range lies above it.
By their numbers in this assay, from the lowest: compound 4; then compound 2; then compound 1.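

Until this point, changes at this position had shifted the number only modestly or, in compound 3, left no number at all, whereas in this assay the six-membered non-aromatic ring with 1 hetero atom brings a far larger drop, with a 53-fold lower number from compound 2 to compound 4 (1.72 log units; beyond the scatter) and a 130-fold lower number from compound 1 to compound 4 (2.12 log units; beyond the scatter) as the two measured steps. A low number on this aromatic carbon therefore does not require an aromatic ring in the group: compound 4, whose group has none, has the lowest number of the compounds shown, while compound 3 has no number, so the step from it to compound 4 cannot be read. No measurement at hand accounts for the size of this change.

The entering group differs from the benzyl and 3,4-dimethylphenyl groups in several ways at once, including its ring, its double bond and the way it is joined, so the compounds shown leave open which of these matters. A piperidine, which is the same ring without the double bond, and a morpholine, which has an oxygen in the ring, would help to separate these features.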